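Chloro in Place of Methoxy: Cytotoxicity Expected Within Scatter

The source may hold more compounds than are shown below. What is called first, only, known or untested is meant among the compounds shown, and "the series" means these compounds.

The measured compounds and their numbers:
compound 1, `O=S1(=O)C=C(Sc2nnc(-c3cccnc3)o2)c2ccccc21`, 14000 nM
compound 2, `CC(=O)Nc1ccc(-c2nnc(SC3=CS(=O)(=O)c4ccccc43)o2)cc1`, 31000 nM
compound 3, `COc1cccc(-c2nnc(SC3=CS(=O)(=O)c4ccccc43)o2)c1`, 20000 nM

These three share one core and differ only in the aromatic group attached to it. In an ADME assay on HepG2 cells (Homo sapiens) for cytotoxicity, read by fluorescence and resazurin assay, with a stated time of 24 h (a lower number here means that less compound is tolerated, a higher number that more compound is tolerated), compound 3 holds the second highest of the three numbers. Its nearest neighbour is compound 1, and the step of a 1.4-fold higher number from compound 1 to compound 3 (0.15 log units; within the scatter) is within the scatter; compound 2 is furthest away, with a higher number that is also within the scatter. Among the measured compounds shown here, no measured pair therefore separates cleanly on this read-out.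

Compound 4, `O=S1(=O)C=C(Sc2nnc(-c3cccc(Cl)c3)o2)c2ccccc21`, is not yet measured. Relative to compound 3 the change is chloro in place of methoxy on an aromatic carbon.

For the measured compounds named here, only one measured step touches the same aromatic position: the exchange from compound 1 to compound 3, which gave a 1.4-fold higher number from compound 1 to compound 3 (0.15 log units; within the scatter) and stayed within the scatter. Going by the values given here, no measured step brings chloro in for methoxy, so the bearing of that step is indirect. Given that a replacement at this position from compound 1 to compound 3 moved the number by a 1.4-fold higher number from compound 1 to compound 3 (0.15 log units; within the scatter), no step beyond the scatter is expected here, and compound 4 is estimated at a 1.1-fold lower number from compound 3 to compound 4 (0.05 log units; within the scatter) from compound 3. For compound 4 the expected number in this assay is 18000 nM, with a range from 9000 nM to 40000 nM.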

Compound 4, half-maximal cytotoxic concentration: 27000 nM
For compound 4 the middle estimate is 1.5-fold (0.18 log units) below the measured one; measured number inside the range.
By their numbers in this assay, from the lowest: compounds 1, 3, 4 and 2 (each within the scatter of the next, the first and the last beyond it).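

In this assay, among the compounds shown here, chloro in place of methoxy on an aromatic carbon gave a 1.4-fold higher number from compound 3 to compound 4 (0.13 log units; within the scatter), the first measured step that takes methoxy away from this place and puts a single chlorine atom there. 3-Chlorophenyl in place of pyridin-3-yl gave a 1.9-fold higher number from compound 1 to compound 4 (0.29 log units; within the scatter), so 3-methoxyphenyl, 3-chlorophenyl and pyridin-3-yl now stand within the scatter of one another, and none of the three steps among compounds 1, 3 and 4 separates cleanly on this read-out. Nothing in the available information accounts for where these numbers fall.

The compounds shown leave open whether a group of another kind on this aromatic carbon, such as an amine, a carboxylic acid or a longer chain, would give a step beyond the scatter, since chloro and methoxy are the only two such substituents compared here. They also leave open whether the closeness of compounds 1, 3 and 4 holds in any cell type other than the one used in this assay or at any other exposure time.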